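Furan versus benzofuran on a ribosyl pyrrolopyrimidine series

The source may hold more compounds than are shown below. What is called first, only, known or untested is meant among the compounds shown, and "the series" means these compounds.

Measured compounds:
compound 1 `O=c1[nH]cnc2c1c(-c1ccco1)cn2[C@@H]1O[C@H](CO)[C@@H](O)[C@H]1O` — 5780 nM
compound 2 `O=c1[nH]cnc2c1c(-c1cc3ccccc3o1)cn2[C@@H]1O[C@H](CO)[C@@H](O)[C@H]1O` — > 20000 nM (a limit)
compound 3 `CNc1ncnc2c1c(-c1cc3ccccc3o1)cn2[C@@H]1O[C@H](CO)[C@@H](O)[C@H]1O` — > 20000 nM (a limit)

In a functional assay on HeLa S3 cells (Homo sapiens) for antiproliferative activity, read by XTT assay, with a stated time of 72 h (on this read-out lower numbers stand for stronger inhibition and higher numbers for weaker inhibition), compound 1 gives 5780 nM. For compound 2 the read-out is only a limit, > 20000 nM. For compound 3 likewise only a limit is reported, > 20000 nM. Going by the values given here, the one measured step is an at least 3.4-fold lower number from compound 2 to compound 1 (0.53 log units; beyond the scatter), the change being (furan-2-yl in place of 1-benzofuran-2-yl on an aromatic carbon). How the core of compound 2 differs from that of compound 3 is not broken down here.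

Compound 4 `CNc1ncnc2c1c(-c1ccco1)cn2[C@@H]1O[C@H](CO)[C@@H](O)[C@H]1O` carries the same change from compound 3: furan-2-yl in place of 1-benzofuran-2-yl on an aromatic carbon. In this assay the expected step is an at least 2.5-fold lower number from compound 3 to compound 4 (0.39 log units; beyond the scatter), resting on an at least 3.4-fold lower number from compound 2 to compound 1 (0.53 log units; beyond the scatter); its starting point is uncertain because the limit of > 20000 nM in this assay, at which 2 of the 3 values shown sit, leaves the value of compound 3 open. Compound 4 is therefore estimated at 8000 nM, between 2000 nM and 30000 nM.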

Compound 4, half-maximal inhibitory concentration: 5000 nM
The estimate for compound 4 lay 1.6-fold (0.20 log units) above the measured number; the range from low to high includes it.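

In this assay furan-2-yl in place of 1-benzofuran-2-yl gives an at least 4.0-fold lower number from compound 3 to compound 4 (0.60 log units; beyond the scatter), the same direction as on the core of compound 1. Compound 3 stands at > 20000 nM, a limit and not a number, and the size of this step is therefore open at its upper end. Direction carries across these two cores, but equal size is not shown: the same change on two cores in this assay, an at least 3.4-fold lower number (0.53 log units; beyond the scatter) from compound 2 to compound 1 and an at least 4.0-fold lower number (0.60 log units; beyond the scatter) from compound 3 to compound 4; the limit leaves it open whether they differ

On these data alone, how far the 1-benzofuran-2-yl compounds lie past their shared limit stays open: the limit of > 20000 nM in this assay, at which 2 of the 4 values shown sit. Also open is how a phenyl or a thiophen-2-yl group would read on the same aromatic carbon of either core.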